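Removing the trifluoromethyl group: expected solubility of compound 3

The source may report more compounds than this note shows. Statements on the series, on what has been measured and on what is new or still open speak of the compounds shown alone.

The measured compounds in a physicochemical assay for solubility, at pH 2 (on this read-out lower numbers stand for lower solubility and higher numbers for higher solubility), are:
compound 1, `CNc1nc(NCCCN(C)C)c2sc(-c3ccc(C(F)(F)F)cc3)cc2n1`, 240 ug/mL
compound 2, `CNc1nc(NCCCN(C)C)c2sc(-c3ccc(N)cc3)cc2n1`, > 100 ug/mL

Among the compounds with values here, compound 1 holds the only plain number in this assay. For compound 2 the result is a limit of the assay, not a number, and the reading the limit of > 100 ug/mL in this assay, at which 1 of the 2 values shown sits, is all that is known of it. The step that the limit leaves unreadable from compound 1 to compound 2 therefore cannot be read, and the change amino in place of trifluoromethyl on an aromatic carbon gives no usable size.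

Compound 3, `CNc1nc(NCCCN(C)C)c2sc(-c3ccccc3)cc2n1`, has not yet been measured. It differs from compound 1 by hydrogen in place of trifluoromethyl on an aromatic carbon. No measured step bears readably on this change, so nothing shown points to a shift in either direction beyond the usual scatter. Compound 3 is expected to give 300 ug/mL, within 130 ug/mL to 700 ug/mL. The estimated step of a 1.3-fold higher number from compound 1 to compound 3 (0.10 log units; within the scatter) is thus expected to stay close to the scatter of the assay.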

Compound 3, solubility: > 100 ug/mL
Compound 3: a limit, no number; the forecaster's own chance of this, stated with the estimate: 25%; the middle value does not contradict the limit.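

In this assay compound 3 gives > 100 ug/mL as a limit of the assay, not a number. Within the data shown here, no step among compound 1, compound 2 and compound 3 can therefore be read. The compounds shown leave open how far the solubility of compound 2 and compound 3 differs from that of compound 1.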